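This account rests on a few compounds, and the source may have more. Where it says the series, first, only, none or still open, it means among the compounds named here.

Compound 1 `CS(=O)(=O)Cc1cccc2c1CCC2c1ncc[nH]1`: in an in vitro ADME assay on microsomes from liver (Homo sapiens) for metabolic stability (on this read-out lower numbers stand for slow clearance and higher numbers for fast clearance), compound 1 gives < 7 mL.min-1.g-1.
Compound 2 `COCCc1cccc2c1CCC2c1ncc[nH]1`: in this assay compound 2 gives 38 mL.min-1.g-1.
Compound 3 `c1cc(Cn2ccnn2)c2c(c1)C(c1ncc[nH]1)CC2`: in this assay compound 3 gives "not determined" (no result reported).

The value of compound 1 is a limit of this assay, not a number, as noted in the limit of < 7 mL.min-1.g-1 in this assay, at which 1 of the 3 values shown sits. Compound 3 has no value here; it stands without a number. Compound 4 `Fc1ccn(Cc2cccc3c2CCC3c2ncc[nH]2)n1` differs from compound 3 by 3-fluoro-1H-pyrazol-1-yl in place of 1H-1,2,3-triazol-1-yl on a saturated chain carbon bound to an aromatic carbon. Among the compounds with values here, the only measured step, an at least 5.4-fold higher number from compound 1 to compound 2 (0.73 log units; beyond the scatter), concerns a different pair of groups at the same kind of position, so it does not bear directly on this change. Within the data shown here, no step of the same kind has been measured, and no direction beyond the scatter is expected. Compound 4 is estimated to give roughly 25 mL.min-1.g-1, within 8 mL.min-1.g-1 to 80 mL.min-1.g-1.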

Compound 4, intrinsic clearance in microsomes: 30 mL.min-1.g-1
Estimate against measurement, compound 4: 1.2-fold (0.08 log units) below; low and high end bracket the measured number.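

In this assay, a five-membered aromatic ring at this position, the 3-fluoro-1H-pyrazol-1-yl of compound 4, gives a result that cannot be told apart from the methoxymethyl result: a 1.3-fold lower number from compound 2 to compound 4 (0.10 log units; within the scatter). Methylsulfonyl therefore stands apart from both groups, as it did from methoxymethyl alone: an at least 4.2-fold higher number from compound 1 to compound 4 (0.63 log units; beyond the scatter). The value of compound 1 is a limit, not a number: the limit of < 7 mL.min-1.g-1 in this assay, at which 1 of the 4 values shown sits.

Compound 3 has no number, so the step from the 1H-1,2,3-triazol-1-yl to the 3-fluoro-1H-pyrazol-1-yl cannot be read. Where an amine or a carboxylic acid on this chain carbon would fall remains open.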